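Amide group variation on a shared core

A few compounds are considered here, and "the series" means these few. Any claim that something is new, unique, unknown or untested is made for them only; others in the source may bear on it.

Measured compounds:
compound 1 `CCc1ccc(C(=O)NC[C@H]2c3[nH]c4ccccc4c3C[C@H]3[C@H]4c5[nH]c6ccccc6c5C[C@@H]([C@H](C#N)N23)N4C)cc1` — 670 nM
compound 2 `CN1[C@@H]2c3[nH]c4ccccc4c3C[C@H]1[C@H](C#N)N1[C@@H](CNC(=O)c3cccc4c3CCCC4)c3[nH]c4ccccc4c3C[C@@H]21` — 810 nM
compound 3 `CN1[C@@H]2c3[nH]c4ccccc4c3C[C@H]1[C@H](C#N)N1[C@@H](CNC(=O)c3cc4ccccc4o3)c3[nH]c4ccccc4c3C[C@@H]21` — 230 nM

In a functional assay on A2780 cells (Homo sapiens) for cytotoxicity, read by MTT assay, with a stated time of 72 h (on this read-out lower numbers stand for stronger inhibition and higher numbers for weaker inhibition), compound 3 gives 230 nM, the lowest of the three numbers. The steps that lead to it, a 2.9-fold lower number from compound 1 to compound 3 (0.46 log units; beyond the scatter) and a 3.5-fold lower number from compound 2 to compound 3 (0.55 log units; beyond the scatter), both lie beyond the scatter, while the step of a 1.2-fold higher number from compound 1 to compound 2 (0.08 log units; within the scatter) does not.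

Compound 4 `CN1[C@@H]2c3[nH]c4ccccc4c3C[C@H]1[C@H](C#N)N1[C@@H](CNC(=O)/C=C/c3cccc(C(F)(F)F)c3)c3[nH]c4ccccc4c3C[C@@H]21` differs from compound 3 by 2-(3-(trifluoromethyl)phenyl)ethenyl in place of 1-benzofuran-2-yl on a carbonyl carbon. Going by the values given here, no measured step involves a 2-(3-(trifluoromethyl)phenyl)ethenyl group; the two steps that bear on the question show only that the 1-benzofuran-2-yl amide gave a lower number than the other two aryl amides. Compound 4 is therefore expected to give a higher number than compound 3, closer to the other two, a step of a 2.2-fold higher number from compound 3 to compound 4 (0.34 log units; beyond the scatter). Compound 4 is estimated at 500 nM, with a range of 150 nM to 1600 nM.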

Compound 4, half-maximal inhibitory concentration: > 10000 nM
Compound 4 was reported as a limit; the forecaster's own chance of this, stated with the estimate: 5%; middle value at least 20-fold (1.30 log units) from the limit.
By their numbers in this assay, from the lowest: compound 3; then compounds 1 and 2 (each within the scatter of the next). At a limit, above all of these: compound 4.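

Among the earlier compounds, changing the group on the carbonyl carbon moved the number only modestly or not beyond the scatter, but the 2-(3-(trifluoromethyl)phenyl)ethenyl group shows that this position can tolerate far less: there is an at least 43-fold higher number from compound 3 to compound 4 (1.63 log units; beyond the scatter), an at least 12-fold higher number from compound 2 to compound 4 (1.09 log units; beyond the scatter) and an at least 14-fold higher number from compound 1 to compound 4 (1.17 log units; beyond the scatter). Compound 4 is reported only as a limit: the limit of > 10000 nM in this assay, at which 1 of the 4 values shown sits.

The compounds shown do not separate the contribution of the ethenyl double bond from that of the trifluoromethyl group. On these data alone, how a 2-phenylethenyl amide without trifluoromethyl would read remains open, as does the effect of an aryl amide carrying an amine.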